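One Stereocentre Flipped at a Saturated Ring Carbon

A few compounds are considered here, and "the series" means these few. Any claim that something is new, unique, unknown or untested is made for them only; others in the source may bear on it.

In a functional assay on DLD-1 cells (Homo sapiens) for inhibition, read by luminescence, with a stated time of 3 days (a higher number here means a weaker inhibitor of growth, a lower number a stronger inhibitor of growth), compound 1 `CC(=O)N1CCN(C(=O)[C@@H]2CC[C@@H](C)N2C(=O)C2=C(C(C)C)N3C(=N[C@@](C)(c4ccc(Cl)cc4)[C@H]3c3ccc(Cl)cc3)S2)CC1` gives 16000 nM and compound 2 `CC(=O)N1CCN(C(=O)[C@@H]2CC[C@@H](C)N2C(=O)C2=C(C(C)C)N3C(=N[C@@](C)(c4ccc(Cl)cc4)[C@H]3c3ccc(Cl)cc3)S2)C[C@H]1C` gives 11000 nM, so compound 2 stands level with compound 1 within the scatter. Compound 3 `CC(=O)N1CCN(C(=O)[C@@H]2CC[C@@H](C)N2C(=O)C2=C(C(C)C)N3C(=N[C@@](C)(c4ccc(Cl)cc4)[C@H]3c3ccc(Cl)cc3)S2)C[C@@H]1C` departs from compound 2 in one way: the two compounds have the same atoms and bonds and differ only in configuration as drawn: 1 of 5 stereo elements differ; a stereocentre at a saturated ring carbon is drawn R in compound 2 and S in compound 3. Among the measured compounds shown here, the one measured step that bears on this, a 1.5-fold lower number from compound 1 to compound 2 (0.16 log units; within the scatter), put methyl in place of hydrogen on a saturated ring carbon. For the measured compounds named here, no measured pair tests a change of configuration alone, so the guide is indirect. The expected step, a 1.1-fold higher number from compound 2 to compound 3 (0.04 log units; within the scatter), has no favoured direction and stays within the scatter. Compound 3 is estimated at 12000 nM, with an expected range of 6000 nM to 24000 nM.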

Compound 3, concentration for 50% growth inhibition in the DLD-1 assay: 5200 nM
Compound 3: the middle estimate sits 2.3-fold (0.36 log units) above what was measured, and the stated range ends above it.
By their numbers in the DLD-1 assay, from the lowest: compound 3; then compounds 2 and 1 (each within the scatter of the next).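

In the DLD-1 assay, flipping this stereocentre gives a 2.1-fold lower number from compound 2 to compound 3 (0.33 log units; beyond the scatter), and methyl drawn S gives a 3.1-fold lower number from compound 1 to compound 3 (0.49 log units; beyond the scatter), so at this ring carbon the configuration of the methyl matters where its mere presence, drawn R, gives a 1.5-fold lower number from compound 1 to compound 2 (0.16 log units; within the scatter). The shift can be assigned to the stereocentre alone because nothing else changes: the fact that compounds 2 and 3 differ only in the configuration as drawn. In a physicochemical assay for solubility, read by HPLC, in phosphate buffer, at pH 6.8 (a higher number here means a more soluble compound, a lower number a less soluble compound), compound 2 gives 72 ug/mL and compound 3 gives 75 ug/mL, and the same flip gives a 1.0-fold higher number from compound 2 to compound 3 (0.02 log units; within the scatter), so the two compounds stand level there. Going by these compounds, whether an ethyl or a hydroxyl group drawn S on this carbon would lower the growth-inhibition number further remains open.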